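The source may report more compounds than this note shows. Statements on the series, on what has been measured and on what is new or still open speak of the compounds shown alone.

Measured compounds in a functional assay on SK-MEL-28 cells (Homo sapiens) for antiproliferative activity, read by sulforhodamine B assay, with a stated time of 48 h; on this read-out lower numbers stand for stronger inhibition and higher numbers for weaker inhibition:
- compound 1, `COc1cc(-c2nn(-c3ccc(NC(=O)c4ccc(Cl)c(Cl)c4)cc3)cc2-c2ccncc2)ccc1Cl`: 40300 nM
- compound 2, `COc1cc(-c2nn(-c3ccc(NC(=O)c4cc(Cl)cc(Cl)c4)cc3)cc2-c2ccncc2)ccc1Cl`: value is a limit of the assay, > 100000 nM
- compound 3, `COc1cc(-c2nn(-c3ccc(NC(=O)c4ccc(Cl)c(C(F)(F)F)c4)cc3)cc2-c2ccncc2)ccc1Cl`: 2800 nM

Compound 2 sits at the limit of this assay, with no number of its own; it is the one entry at the limit of > 100000 nM in this assay, at which 1 of the 3 values shown sits. Among the three measured compounds, compound 3 gives the lowest number, and the steps from the others to it are large: a 14-fold lower number from compound 1 to compound 3 (1.16 log units; beyond the scatter), and an at least 35-fold lower number from compound 2 to compound 3 (1.55 log units; beyond the scatter). The step within the dichlorophenyl pair is smaller but still beyond the scatter: an at least 2.4-fold higher number from compound 1 to compound 2 (0.39 log units; beyond the scatter).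

The unmeasured compound 4, `O=C(Nc1ccc(-n2cc(-c3ccncc3)c(-c3ccc(Cl)c(O)c3)n2)cc1)c1cc(Cl)cc(Cl)c1`, keeps the 3,5-dichlorophenyl amide of compound 2 and changes only the other side of the shared core: hydrogen in place of methyl on an oxygen on an aromatic ring. For the measured compounds named here, none of the measured steps touches this position; all three concern the aryl group on the carbonyl carbon. Going by the values given here, there is therefore no measured step that bears on the change from compound 2 to compound 4, and no step beyond the scatter in this assay is expected from it.

Compound 4 is expected near 100000 nM in this assay, with a range from 30000 nM to 300000 nM. The expected step is a number no higher from compound 2 to compound 4 (the limit leaves the size open), meaning compound 4 is expected to return a limit again, as compound 2 did.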

Compound 4, half-maximal inhibitory concentration: 2750 nM
Estimate against measurement, compound 4: 36-fold (1.56 log units) above, and the stated range ends above it.
By their numbers in this assay, from the lowest: compounds 4 and 3 (each within the scatter of the next); then compound 1. At a limit, above all of these: compound 2.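

In this assay, hydrogen in place of methyl on an oxygen on an aromatic ring gives an at least 36-fold lower number from compound 2 to compound 4 (1.56 log units; beyond the scatter). For the compounds shown here, all earlier steps concerned the aryl group on the carbonyl carbon, and this is the first to show that the other side of the shared core can also move the number by a large step. The 3,5-dichlorophenyl amide, which compound 2 and compound 4 share, therefore does not by itself hold a compound at the limit, and the true size of the step stays open on one side, as compound 2 gives a limit and not a number: the limit of > 100000 nM in this assay, at which 1 of the 4 values shown sits.

The methoxy to hydroxy change rests on this single pair, which leaves open whether it gives a comparable step with the amides of compound 1 and compound 3. Also open, going by these compounds, is whether the hydroxy group itself is needed at this place, or whether an amine or a longer ethoxy chain would give a similar number.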